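Aryl substituent on the piperazine: compound 3

This account rests on a few compounds, and the source may have more. Where it says the series, first, only, none or still open, it means among the compounds named here.

Measured compounds:
compound 1 `CCCc1nc(-c2ccccc2)c(CNCCN2CCN(c3cccc(F)c3)CC2)o1`: 62.3%
compound 2 `CCCc1nc(-c2ccccc2)c(CNCCN2CCN(c3ccccc3C)CC2)o1`: 51.3%

Both were tested in an assay on HEK293 cells for inhibition of Voltage-dependent T-type calcium channel subunit alpha-1G (Homo sapiens), read by fluorescence, tested at 10 uM; on this read-out higher numbers stand for more inhibition at the one concentration tested (going by the name of the read-out) and lower numbers for less inhibition. Within the data shown here, of the two numbers, compound 2 stands lowest; the step of a number 11 percentage points lower from compound 1 to compound 2 (beyond the scatter) lies beyond the usual scatter and is the only step available.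

Compound 3 `CCCc1nc(-c2ccccc2)c(CNCCN2CCN(c3ccccc3)CC2)o1` differs from compound 2 by hydrogen in place of methyl on an aromatic carbon. Among the measured compounds shown here, no measured step removes a methyl from the aryl group on the piperazine; the one step known, a number 11 percentage points lower from compound 1 to compound 2 (beyond the scatter), changes both the kind of substituent and where it sits, so it does not transfer directly to this change. With only that to go on, the expected outcome for compound 3 is a step no larger than the scatter, a number 3.7 percentage points higher from compound 2 to compound 3 (within the scatter), in either direction. Compound 3 is therefore estimated at 55%, with a range from 38% to 70%.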

Compound 3, a percentage reported as inhibition, at one concentration (the size of the read-out at that concentration, not a potency): 54.3%
Estimate against measurement, compound 3: 0.7 percentage points above; low and high end bracket the measured number.
By their numbers in this assay, from the lowest: compounds 2, 3 and 1 (each within the scatter of the next, the first and the last beyond it).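

In this assay, removing either substituent gives a step within the scatter: a number 3 percentage points higher from compound 2 to compound 3 (within the scatter) on losing methyl, and a number 8 percentage points lower from compound 1 to compound 3 (within the scatter) on losing fluoro. The plain phenyl group therefore cannot be separated from either the 2-methylphenyl or the 3-fluorophenyl group, and the gap beyond the scatter appears only between the two substituted compounds, so neither substituent on its own can be credited with it. No supporting data bear on these steps.

On these data alone, compound 1 and compound 2 differ in both the kind of substituent and where it sits, so which of the two carries their gap remains open. Also open, as far as these compounds go, is how this aryl ring would read with a methoxy, a trifluoromethyl or a carboxylic acid group.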